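Methyl to 2-methylcyclopropyl on an amide-type nitrogen

The compounds below may be only part of what the source reports. "The series", "measured", "known", "first", "only" and "open" are said of these compounds alone.

Values in a physicochemical assay for solubility (a higher number here means a more soluble compound, a lower number a less soluble compound), so far:
compound 1 `CCC(=O)N1C[C@@H]2[C@H](C1)[C@H]2NC(=O)c1cc(C(=O)NC)c2c(c1)[C@H](c1ccccc1)CO2` gives >= 163 ug/mL
compound 2 `CNC(=O)c1cc(C(N)=O)cc2c1OC[C@H]2c1ccccc1` gives >= 144 ug/mL
compound 3 `CNC(=O)c1cc(C(=O)NC)c2c(c1)[C@H](c1ccccc1)CO2` gives >= 130 ug/mL

Compound 3 stands at >= 130 ug/mL, which is a limit and not a number. The other two values are limits as well. Compound 4 `CNC(=O)c1cc(C(=O)N[C@H]2C[C@@H]2C)cc2c1OC[C@H]2c1ccccc1` carries 2-methylcyclopropyl in place of methyl on an amide-type nitrogen. Two measured steps change the group on that same nitrogen: a step that the two limits leave unreadable from compound 1 to compound 3 and a step that the two limits leave unreadable from compound 2 to compound 3. Neither gives a size, so they offer no sign of a direction. The expected change is therefore none beyond the scatter, as an at least 1.1-fold lower number from compound 3 to compound 4 (0.07 log units; that floor lies within the scatter). Compound 4 is estimated at 110 ug/mL, with an expected range from 35 ug/mL to 170 ug/mL.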

Compound 4, solubility: >= 76 ug/mL
Compound 4: a limit, no number; the forecaster's own chance of this, stated with the estimate: 45%; the middle value lies beyond the limit too.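

In this assay compound 4 gives >= 76 ug/mL, which is a limit and not a number. Compound 1, compound 2 and compound 3 also stand only as limits, so none of their steps to compound 4 can be read. The compounds shown leave open whether 2-methylcyclopropyl in place of methyl on the amide-type nitrogen changes the read-out in this assay at all, and in which direction.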